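Piperidinylmethyl for methoxy on the N-aryl ring

The compounds below may be only part of what the source reports. "The series", "measured", "known", "first", "only" and "open" are said of these compounds alone.

Compound 2 `CCOC(=O)C1=C(C)N/C(=C/c2cc(C)n(-c3ccc(OC)cc3)c2C)C1=O` sits second highest of the three numbers in a physicochemical assay for lipophilicity, read by HPLC, at pH 7.4; on this read-out lower numbers stand for lower lipophilicity and higher numbers for higher lipophilicity: compound 2 gives 3. Compound 1 `CCOC(=O)C1=C(C)N/C(=C/c2cc(C)n(-c3cccc(C(F)(F)F)c3)c2C)C1=O` gives 3.4, and compound 3 `CCOC(=O)C1=C(C)N/C(=C/c2cc(C)n(-c3cccnc3)c2C)C1=O` gives 2.1. The steps run a number 0.40 log units lower from compound 1 to compound 2 (beyond the scatter), a number 1.30 log units lower from compound 1 to compound 3 (beyond the scatter) and a number 0.90 log units lower from compound 2 to compound 3 (beyond the scatter).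

Compound 4 `CCOC(=O)C1=C(C)N/C(=C/c2cc(C)n(-c3ccc(CN4CCCCC4)cc3)c2C)C1=O` differs from compound 2 by (piperidin-1-yl)methyl in place of methoxy on an aromatic carbon. Among the measured compounds shown here, no measured step exchanges a substituent on this ring; all three swap the whole aryl group on the aromatic nitrogen. The nearest guide is the step from compound 2 to compound 3, where bringing a ring nitrogen into the aryl group lowered this assay by a number 0.90 log units lower from compound 2 to compound 3 (beyond the scatter). Nothing measured shows how a (piperidin-1-yl)methyl group behaves in this series, so the expectation is drawn loosely and with a wide range. A step downward in this assay is expected for compound 4, estimated as a number 1.00 log units lower from compound 2 to compound 4 (beyond the scatter). Compound 4 is therefore estimated at 2, within 1.2 to 2.8.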

Compound 4, distribution coefficient: 8.5
The estimate for compound 4 lay 6.50 log units below the measured number; the whole stated range lies below it.
By their numbers in this assay, from the lowest: compound 3; then compound 2; then compound 1; then compound 4.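

In this assay, among the compounds shown here, the first exchange on the aromatic carbon of this ring, para to a large group, gives a number 5.50 log units higher from compound 2 to compound 4 (beyond the scatter) and so exceeds every step among the earlier compounds, the largest of which is a number 1.30 log units lower from compound 1 to compound 3 (beyond the scatter) on swapping the whole aryl group. The downward step seen when a ring nitrogen entered the aryl group, a number 0.90 log units lower from compound 2 to compound 3 (beyond the scatter), therefore does not carry over to the nitrogen of a (piperidin-1-yl)methyl group, and this series offers no single direction for nitrogen-bearing groups on the aryl group. Nothing on hand explains the size or direction of this step.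

From the compounds shown here alone, it remains open whether the step belongs to the piperidine ring, the methylene link or the nitrogen itself. A morpholin-4-ylmethyl group or a dimethylaminomethyl group at the same place would help separate these parts.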